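Trifluoromethyl for methoxy, carried into the oxime series

A few compounds are considered here, and "the series" means these few. Any claim that something is new, unique, unknown or untested is made for them only; others in the source may bear on it.

Compound 1 `CCCCCc1ccc2[nH]c(-c3ccc(OC)cc3)c(C=O)c2c1` is the reference point in a functional assay on MCF7 cells (Homo sapiens) for antiproliferative activity, with a stated time of 5 days (a higher number here means a weaker inhibitor, a lower number a stronger inhibitor), where compound 1 gives 20 nM. Compound 2 `CCCCCc1ccc2[nH]c(-c3ccc(C(F)(F)F)cc3)c(C=O)c2c1` carries the change (trifluoromethyl in place of methoxy on an aromatic carbon); in this assay compound 2 gives 67 nM, and the step is a 3.4-fold higher number from compound 1 to compound 2 (0.53 log units; beyond the scatter). Compound 3 `CCCCc1ccc2[nH]c(-c3ccc(OC)cc3)c(/C=N\O)c2c1` keeps the methoxy group of compound 1 but differs in the core; the difference between the two cores is not broken down here. In this assay compound 3 gives 212 nM, the highest number of the three measured compounds, with both steps to it beyond the scatter. Compound 4 `CCCCc1ccc2[nH]c(-c3ccc(C(F)(F)F)cc3)c(/C=N\O)c2c1` differs from compound 3 by trifluoromethyl in place of methoxy on an aromatic carbon, the same change as that between compound 1 and compound 2, at a place described in identical words. Within the data shown here, only one measured pair carries this change, so the expectation rests on it alone. The expected step is a 3.3-fold higher number from compound 3 to compound 4 (0.52 log units; beyond the scatter), because a 3.4-fold higher number from compound 1 to compound 2 (0.53 log units; beyond the scatter) lay beyond the scatter for the same change, and a step of similar size is assumed to carry over. Compound 4 is accordingly estimated at 700 nM in this assay, with the expected range running from 250 nM to 2000 nM.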

Compound 4, half-maximal inhibitory concentration: 1660 nM
For compound 4 the middle estimate is 2.4-fold (0.38 log units) below the measured one, and the stated range covers the measured number.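

In this assay, trifluoromethyl in place of methoxy again gives a weaker result, with a 7.8-fold higher number from compound 3 to compound 4 (0.89 log units; beyond the scatter), so the change moves in the same direction on both cores shown. The two steps cannot be told apart in size, and the larger figure on the core of compound 3 is no evidence that the core alters the effect of the change: the same change on two cores in this assay, a 3.4-fold higher number (0.53 log units; beyond the scatter) from compound 1 to compound 2 and a 7.8-fold higher number (0.89 log units; beyond the scatter) from compound 3 to compound 4, 2.3-fold (0.37 log units) apart, within the scatter of two such steps. Among these compounds, with only two pairs in one assay, this supports carrying the change between these two cores but does not show that it would hold on any further core or in another assay.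

Still open, on these data alone, is whether other groups at this place, such as a chlorine atom, an amine or a carboxylic acid, would behave alike on both cores. Compound 1 and compound 3 differ in both the chain and the aldehyde or oxime group, and the share of each in their difference remains unresolved.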